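Amide series on the shared bicyclic core: cyclopropyl in place of propyl

The source may report more compounds than this note shows. Statements on the series, on what has been measured and on what is new or still open speak of the compounds shown alone.

Measured compounds:
compound 1 `CCC(=O)N1CC2CC(C1)N2`: 6 nM
compound 2 `CCCC(=O)N1CC2CC(C1)N2`: 14 nM
compound 3 `O=C([C@H]1C[C@@H]1F)N1CC2CC(C1)N2`: 5.4 nM

All three were read in an assay on SH-EP1 cells for displacement of a labelled ligand from Neuronal acetylcholine receptor; alpha4/beta2 (Homo sapiens), read by scintillation counting; a higher number here means a weaker inhibitor, a lower number a stronger inhibitor. Compound 2 gives 14 nM, the highest of the three numbers; the nearest is compound 1 at a 2.3-fold higher number from compound 1 to compound 2 (0.37 log units; beyond the scatter) in reverse, and the furthest is compound 3, reached by a 2.6-fold lower number from compound 2 to compound 3 (0.41 log units; beyond the scatter). Compound 1 and compound 3 sit within the scatter of each other, as a 1.1-fold lower number from compound 1 to compound 3 (0.05 log units; within the scatter) shows.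

The next compound, compound 4 `C[C@H]1C[C@@H]1C(=O)N1CC2CC(C1)N2`, differs from compound 2 as follows: 2-methylcyclopropyl in place of propyl on a carbonyl carbon.

Going by the values given here, two measured steps bear on this. The step from compound 2 to compound 3 replaces the same propyl with a 2-fluorocyclopropyl and gave a 2.6-fold lower number from compound 2 to compound 3 (0.41 log units; beyond the scatter). The step from compound 1 to compound 2 shows that lengthening the chain by a methyl gave a 2.3-fold higher number from compound 1 to compound 2 (0.37 log units; beyond the scatter), so removing chain length tends to lower the number. A 2-methylcyclopropyl in place of propyl is expected to behave much like the 2-fluorocyclopropyl case, giving a modest lowering in this assay, a 2.0-fold lower number from compound 2 to compound 4 (0.30 log units; within the scatter), rather than no change.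

Compound 4 is therefore estimated at 7 nM in this assay, with a range from 3 nM to 16 nM.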

Compound 4, inhibition constant: 17 nM
The estimate for compound 4 lay 2.4-fold (0.39 log units) below the measured number, and the stated range ends below it.
By their numbers in this assay, from the lowest: compounds 3 and 1 (each within the scatter of the next); then compounds 2 and 4 (each within the scatter of the next).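

In this assay, replacing propyl with 2-methylcyclopropyl on the carbonyl carbon gives a result within the scatter (a 1.2-fold higher number from compound 2 to compound 4 (0.08 log units; within the scatter)), so the presence of a three-membered ring alone does not reproduce the lower number of compound 3. The substituent on that ring separates the two ring amides: methyl in place of fluoro on a saturated ring carbon gives a 3.1-fold higher number from compound 3 to compound 4 (0.50 log units; beyond the scatter), and 2-methylcyclopropyl in place of ethyl gives a 2.8-fold higher number from compound 1 to compound 4 (0.45 log units; beyond the scatter), placing compound 4 with the propyl amide, compound 2, rather than with compound 1 or compound 3. Nothing available explains why methyl and fluoro on the ring part in this way.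

The compounds shown leave open where the unsubstituted cyclopropyl, a 2-hydroxycyclopropyl or a 2-(trifluoromethyl)cyclopropyl would fall relative to these two pairs. They also leave open whether other stereoisomers of the 2-methylcyclopropyl and 2-fluorocyclopropyl groups keep this separation, and whether a butyl chain on the same carbonyl carbon would extend the change seen from ethyl to propyl.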